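This account rests on a few compounds, and the source may have more. Where it says the series, first, only, none or still open, it means among the compounds named here.

Compound 1, `CC(C)c1n[nH]c2c(NCc3ccc(-c4ccccn4)cc3)nc(SCC(N)CN)nc12`, gives 480 nM.
Compound 2, `CC(C)c1n[nH]c2c(NCc3ccc(-c4ccccn4)cc3)nc(SC3CCCCC3O)nc12`, gives 636 nM.
Compound 3, `CC(C)c1n[nH]c2c(NCc3ccc(-c4ccccn4)cc3)nc(SCC(N)=O)nc12`, gives 192 nM.

These three share one core and differ only in the group attached to the sulfur. In a functional assay on HT cells (Homo sapiens) for antiproliferative activity, read by fluorescence, with a stated time of 72 h (a higher number here means a weaker inhibitor of growth, a lower number a stronger inhibitor of growth), compound 3 has the lowest of the three numbers: the step of a 2.5-fold lower number from compound 1 to compound 3 (0.40 log units; beyond the scatter) and the step of a 3.3-fold lower number from compound 2 to compound 3 (0.52 log units; beyond the scatter) both lie beyond the scatter, whereas the step of a 1.3-fold higher number from compound 1 to compound 2 (0.12 log units; within the scatter) does not, so compound 1 and compound 2 cannot be put in order against each other. Compound 4, `CC(C)c1n[nH]c2c(NCc3ccc(-c4ccccn4)cc3)nc(SC3CCCCC3N)nc12`, has not yet been measured. It differs from compound 3 in one place: 2-aminocyclohexyl in place of carbamoylmethyl on a sulfur. The group that enters is a six-membered ring closely resembling the 2-hydroxycyclohexyl of compound 2, and both compound 1 and compound 2 give higher numbers than compound 3. Compound 4 is therefore expected to give a higher number, a step of a 2.6-fold higher number from compound 3 to compound 4 (0.42 log units; beyond the scatter) back toward where compound 1 and compound 2 stand. The estimate for compound 4 is 500 nM, within the range from 200 nM to 1300 nM.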

Compound 4, concentration for 50% growth inhibition: 139 nM
Compound 4: the middle estimate sits 3.6-fold (0.56 log units) above what was measured, and the stated range ends above it.
By their numbers in this assay, from the lowest: compounds 4 and 3 (each within the scatter of the next); then compounds 1 and 2 (each within the scatter of the next).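

Amino in place of hydroxy on a saturated ring carbon, with the rest of the group on the sulfur unchanged, gives a 4.6-fold lower number from compound 2 to compound 4 (0.66 log units; beyond the scatter), so this one change on the ring is enough to move the number beyond the scatter. The six-membered ring also fits at this position: 2-aminocyclohexyl in place of carbamoylmethyl gives a 1.4-fold lower number from compound 3 to compound 4 (0.14 log units; within the scatter), which leaves compound 3 and compound 4 unordered, while the amino groups of 2,3-diaminopropyl do not match this result, as a 3.5-fold lower number from compound 1 to compound 4 (0.54 log units; beyond the scatter) shows. No measurement here explains these differences.

From the compounds shown here alone, whether the amino group needs the ring remains open, and plain cyclohexyl or 2-aminoethyl on the sulfur would help separate the two. A carboxylic acid in place of the amide of carbamoylmethyl is also untested among the compounds shown.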